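The source may hold more compounds than are shown below. What is called first, only, known or untested is meant among the compounds shown, and "the series" means these compounds.

Measured so far:
- Compound 1 `CC(C(=O)NCc1ccc(C(F)(F)F)nc1-c1cccc(Cl)c1)c1ccc(NS(C)(=O)=O)c(F)c1`: 0.5 nM
- Compound 2 `COc1ccc(-c2nc(C(F)(F)F)ccc2CNC(=O)C(C)c2ccc(NS(C)(=O)=O)c(F)c2)cc1F`: 4.2 nM
- Compound 3 `COc1ccc(-c2nc(C(F)(F)F)ccc2CNC(=O)C(C)c2ccc(NS(C)(=O)=O)c(F)c2)cc1OC`: 25.6 nM

All three share one core and differ only in the aromatic group that sits on it. In an assay on CHO cells for antagonist activity at transient receptor potential cation channel subfamily V member 1 (Homo sapiens), read by FLIPR (on this read-out higher numbers stand for weaker inhibition and lower numbers for stronger inhibition), compound 3 stands highest of the three numbers, that is, it is the weakest inhibitor here: its nearest neighbour is compound 2, with a 6.1-fold higher number from compound 2 to compound 3 (0.78 log units; beyond the scatter) separating them, and the furthest is compound 1, with a 51-fold higher number from compound 1 to compound 3 (1.71 log units; beyond the scatter).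

Compound 4 `CC(C(=O)NCc1ccc(C(F)(F)F)nc1-c1ccco1)c1ccc(NS(C)(=O)=O)c(F)c1` is not yet measured. It changes that same position: furan-2-yl in place of 3,4-dimethoxyphenyl on an aromatic carbon. The earlier steps shown here that bear on this are those that swapped the group at this position. From compound 1, with its small chlorinated ring, to compound 3, with two methoxy groups, the number rose by a 51-fold higher number from compound 1 to compound 3 (1.71 log units; beyond the scatter); from compound 2 to compound 3, where one methoxy replaced a fluorine, it rose by a 6.1-fold higher number from compound 2 to compound 3 (0.78 log units; beyond the scatter). Both steps that added methoxy groups made the number worse. Compound 4 removes both methoxy groups and brings in a smaller five-membered ring, so the number is expected to fall, by roughly a 6.4-fold lower number from compound 3 to compound 4 (0.81 log units; beyond the scatter). Among the compounds with values here, the estimate for compound 4 in this assay is 4 nM, with an expected range from 0.6 nM to 30 nM; the uncertainty is wide because no measured compound carries a five-membered ring at this position.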

Compound 4, inhibition constant: 5.8 nM
For compound 4 the middle estimate is 1.5-fold (0.16 log units) below the measured one; the range from low to high includes it.
By their numbers in this assay, from the lowest: compound 1; then compounds 2 and 4 (each within the scatter of the next); then compound 3.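

In this assay, this position turns out not to need a six-membered aromatic ring, since the five-membered furan-2-yl brings a 4.4-fold lower number from compound 3 to compound 4 (0.64 log units; beyond the scatter) and stays close to a substituted phenyl, with a 1.4-fold higher number from compound 2 to compound 4 (0.14 log units; within the scatter). A smaller ring without methoxy groups is still not enough to reach the best number seen here, as the swap for 3-chlorophenyl gives a 12-fold higher number from compound 1 to compound 4 (1.06 log units; beyond the scatter). No measurement shown explains these differences.

From the compounds shown here alone, what remains open is whether the advantage of compound 1 comes from its chlorine or from its six-membered ring, and plain phenyl at this position would help to separate the two. A thiophen-2-yl ring, or a furan-2-yl carrying a chlorine, would likewise show whether the five-membered ring can reach the level of compound 1.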